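The source may hold more compounds than are shown below. What is called first, only, known or untested is meant among the compounds shown, and "the series" means these compounds.

In a functional assay on HCT-116 cells (Homo sapiens) for inhibition, read by MTT assay, with a stated time of 72 h (a lower number here means a stronger inhibitor of growth, a higher number a weaker inhibitor of growth), three compounds that share one core have been measured. Compound 1 `CNC(=O)/C=C/c1ccncc1-c1ccc2ccccc2c1`, with methylamino on its carbonyl carbon, gives 6550 nM. Compound 2 `CCOC(=O)/C=C/c1ccncc1-c1ccc2ccccc2c1`, with ethoxy at that carbon, gives 910 nM. Compound 3 `O=C(O)/C=C/c1ccncc1-c1ccc2ccccc2c1`, with hydroxy there, gives > 30000 nM. That value is a limit of the assay and not a number. It places compound 3 as the weakest of the three, with its true value unknown.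

Compound 4 `COC(=O)/C=C/c1ccncc1-c1ccc2ccccc2c1` differs from compound 3 in one place: methyl in place of hydrogen on an oxygen next to a carbonyl group. In words, this is methyl in place of hydrogen on an oxygen next to a carbonyl group. The closest measured step is an at least 32-fold higher number from compound 2 to compound 3 (1.51 log units; beyond the scatter), a large loss when hydrogen replaces ethyl on that same oxygen. The step to compound 4 runs the opposite way, so that step should largely reverse. The move an at least 4.5-fold higher number from compound 1 to compound 3 (0.66 log units; beyond the scatter) also shows hydroxy doing worse than methylamino. Going by the values given here, no measured pair compares methyl directly with ethyl on this oxygen.

A large step towards stronger growth inhibition is therefore expected, estimated as an at least 20-fold lower number from compound 3 to compound 4 (1.30 log units; beyond the scatter). The expectation rests on compound 2 at 910 nM, with a somewhat weaker value allowed for the smaller group. For compound 4, the estimated value in this assay is 1500 nM, with an expected range of 500 nM to 5000 nM.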

Compound 4, concentration for 50% growth inhibition: 350 nM
Compound 4: the middle estimate sits 4.3-fold (0.63 log units) above what was measured; measured number outside the range, below it.
By their numbers in this assay, from the lowest: compound 4; then compound 2; then compound 1. At a limit, above all of these: compound 3.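

Compound 3 stands at a limit of the assay and not at a number, so the step to compound 4 gives only a bound: the limit of > 30000 nM in this assay, at which 1 of the 4 values shown sits.

In this assay, methyl in place of hydrogen on an oxygen next to a carbonyl group gives an at least 85-fold lower number from compound 3 to compound 4 (1.93 log units; beyond the scatter), which shows that the smallest of these two alkyl groups on this oxygen is enough to leave the weak end of the series. Going by these compounds alone, the new result also separates methyl from ethyl at this place, something the earlier compounds could not do, with a 2.6-fold lower number from compound 2 to compound 4 (0.41 log units; beyond the scatter), and it widens the gap to the amide, with a 19-fold lower number from compound 1 to compound 4 (1.27 log units; beyond the scatter), a larger step than a 7.2-fold lower number from compound 1 to compound 2 (0.86 log units; beyond the scatter).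

As far as these compounds go, with only methyl and ethyl on this oxygen, it remains open whether the lower number with the shorter group would extend to other groups there, such as isopropyl, a longer chain or benzyl. On the carbonyl carbon, the plain amine that would give an unsubstituted amide and a dimethylamino group also stand outside these compounds, so the reach of the comparison with methylamino is unsettled.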